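The source may report more compounds than this note shows. Statements on the series, on what has been measured and on what is new or still open speak of the compounds shown alone.

Three compounds share one core, differing only in the aroyl group on the amide. Compound 1 `CCOC(=O)c1sc(-c2cccc(NC(=O)c3ccc(F)cc3)c2)nc1Nc1ccc(N2CCN(C)CC2)cc1` carries a 4-fluorophenyl there; in a functional assay on Raji cells (Homo sapiens) for antiproliferative activity, read by CCK-8 assay, with a stated time of 72 h, tested at 40 uM (a lower number here means less inhibition, a higher number more inhibition at the concentration tested (going by the name of the read-out)), compound 1 gives 16.8%. Compound 2 `CCOC(=O)c1sc(-c2cccc(NC(=O)c3ccccc3)c2)nc1Nc1ccc(N2CCN(C)CC2)cc1` carries an unsubstituted phenyl and gives 42%. Compound 3 `CCOC(=O)c1sc(-c2cccc(NC(=O)c3cccc(F)c3)c2)nc1Nc1ccc(N2CCN(C)CC2)cc1` carries a 3-fluorophenyl and gives 82.8%, the highest of the three, with the steps of a number 40.8 percentage points higher from compound 2 to compound 3 (beyond the scatter) and a number 66 percentage points higher from compound 1 to compound 3 (beyond the scatter) both beyond the scatter.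

Compound 4 `CCOC(=O)c1sc(-c2cccc(NC(=O)c3ccc(F)c(Cl)c3)c2)nc1Nc1ccc(N2CCN(C)CC2)cc1` is not yet measured. It differs from compound 3 in one place: 3-chloro-4-fluorophenyl in place of 3-fluorophenyl on a carbonyl carbon.

Among the measured compounds shown here, two measured steps bear on this. The fluoro entering at the 3-position of the ring gave a number 40.8 percentage points higher from compound 2 to compound 3 (beyond the scatter), a large gain, so the inhibition in this assay is higher with a substituent at that position; compound 4 keeps a substituent there, now chloro. Against this, the fluoro at the 4-position cost activity, since a number 25.2 percentage points higher from compound 1 to compound 2 (beyond the scatter) shows its removal raised the number, and compound 4 carries that 4-fluoro again. For the measured compounds named here, with the two effects pulling in opposite directions and no compound showing both substituents together, a moderate fall from compound 3 is expected, a number 22.8 percentage points lower from compound 3 to compound 4 (beyond the scatter). Compound 4 is therefore estimated at 60%, within a range of 30% to 85%.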

Compound 4, a percentage reported as inhibition, at one concentration (the size of the read-out at that concentration, not a potency): 20.7%
Compound 4: the middle estimate sits 39.3 percentage points above what was measured; the measured number lies below the stated range.
By their numbers in this assay, from the lowest: compounds 1 and 4 (each within the scatter of the next); then compound 2; then compound 3.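

Moving to the 3-chloro-4-fluorophenyl group in this assay gives a number 62.1 percentage points lower from compound 3 to compound 4 (beyond the scatter) and a number 21.3 percentage points lower from compound 2 to compound 4 (beyond the scatter), so a halogen on the ring at the 3-position does not by itself preserve the gain seen with 3-fluorophenyl, and here the reading falls under that of the unsubstituted phenyl. Adding only chloro to the 4-fluorophenyl ring gives a number 3.9 percentage points higher from compound 1 to compound 4 (within the scatter), which leaves the two compounds indistinguishable, and among these four compounds the two carrying the 4-fluoro substituent are the two with the lowest readings. Nothing available explains why this ring substitution has this effect.

From the compounds shown here alone, what remains open is whether the high reading belongs to 3-fluorophenyl specifically or would also appear with 3-chlorophenyl, which would separate the effect of chloro from that of the 4-fluoro substituent. It is also open how other groups on this ring, such as a methoxy group or an amine, would read, and whether the sharp differences among these compounds would hold at concentrations other than the single one tested.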